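The compounds below may be only part of what the source reports. "The series", "measured", "known", "first", "only" and "open" are said of these compounds alone.

The three measured compounds share one core: compound 1 `CCNC(=O)NC1=CS(=O)(=O)O[C@@]12[C@@H](CO[Si](C)(C)C(C)(C)C)O[C@@H](n1cc(C)c(=O)n(C)c1=O)[C@@H]2O[Si](C)(C)C(C)(C)C`, compound 2 `Cc1cn([C@@H]2O[C@H](CO[Si](C)(C)C(C)(C)C)[C@@]3(OS(=O)(=O)C=C3NCCC(=O)OCc3ccccc3)[C@H]2O[Si](C)(C)C(C)(C)C)c(=O)n(C)c1=O` and compound 3 `Cc1cn([C@@H]2O[C@H](CO[Si](C)(C)C(C)(C)C)[C@@]3(OS(=O)(=O)C=C3NC(=O)c3ccccc3)[C@H]2O[Si](C)(C)C(C)(C)C)c(=O)n(C)c1=O`. Compound 4 `COC(=O)C(=O)CNC1=CS(=O)(=O)O[C@@]12[C@@H](CO[Si](C)(C)C(C)(C)C)O[C@@H](n1cc(C)c(=O)n(C)c1=O)[C@@H]2O[Si](C)(C)C(C)(C)C` belongs to the same family and is still to be measured.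

In a functional assay on HEL cells (Homo sapiens) for cytotoxicity, read by microscopy (a lower number here means that less compound is tolerated, a higher number that more compound is tolerated), compound 1 gives >= 3200 nM, which is a limit of the assay and not a number. In this assay compound 2 gives >= 400000 nM, again a limit. In this assay compound 3 gives >= 3200 nM, once more a limit. The steps among the three are therefore not readable: a step that the two limits leave unreadable from compound 1 to compound 2, a step that the two limits leave unreadable from compound 1 to compound 3 and a step that the two limits leave unreadable from compound 2 to compound 3. This follows because the limit of >= 3200 nM in this assay, at which 2 of the 3 values shown sit, holds two of the readings and the limit of >= 400000 nM in this assay, at which 1 of the 3 values shown sits, the third. Compound 3 thus stands at a limit, and the two further values shown are limits as well.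

The move from compound 3 to compound 4 is ((methoxycarbonyl)carbonyl)methyl in place of benzoyl on an amine nitrogen. Among the compounds with values here, no measured step bears on this change in a readable way, so no size or direction beyond the scatter can be expected from the measured steps; the most likely outcome is that compound 4 is again reported as a limit. Compound 4 is therefore estimated at 3200 nM, with a range from 1000 nM to 400000 nM. This estimate corresponds to the expected step of a number no higher from compound 3 to compound 4 (the limit leaves the size open).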

Compound 4, minimum cytotoxic concentration: > 400000 nM
Compound 4: only a limit was reported (the forecaster's own chance of this, stated with the estimate: 85%); middle value at least 120-fold (2.09 log units) away from the limit.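

In this assay compound 4 gives > 400000 nM, which is a limit of the assay and not a number. The steps joining compound 4 to compound 1, compound 2 and compound 3 cannot be read. The compounds shown leave open what concentration of any of the four is first cytotoxic, and whether changing the group on the amine nitrogen shifts that concentration at all.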